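Hydroxymethyl in place of pyrazolyl on a shared imide core

The source may hold more compounds than are shown below. What is called first, only, known or untested is meant among the compounds shown, and "the series" means these compounds.

Compound 1 `Cc1noc(-c2nc(C)c3c(c2N)C(=O)N(Cc2ccc(-n4cccn4)cc2)C3=O)n1`: in a physicochemical assay for solubility, using the shake flask method, in simulated intestinal fluid, measured as kinetic solubility, with a stated time of 2 h, at 25 degrees C, at pH 6.5 (a lower number here means a less soluble compound, a higher number a more soluble compound), compound 1 gives < 5000 nM, a limit of the assay.
Compound 2 `COc1ccc(CN2C(=O)c3c(C)nc(-c4nc(C)no4)c(N)c3C2=O)cc1`: in this assay compound 2 gives < 5000 nM, a limit.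
Compound 3 `Cc1noc(-c2nc(C)c3c(c2N)C(=O)N(Cc2cccc(C(F)(F)F)c2)C3=O)n1`: in this assay compound 3 gives < 5000 nM, a limit.

Compound 1 stands only at a limit, as the limit of < 5000 nM in this assay, at which 3 of the 3 values shown sit, shows. The step that the two limits leave unreadable from compound 1 to compound 2 and the step that the two limits leave unreadable from compound 2 to compound 3 are therefore both unreadable. Compound 4 `Cc1noc(-c2nc(C)c3c(c2N)C(=O)N(Cc2ccc(CO)cc2)C3=O)n1` differs from compound 1 by hydroxymethyl in place of 1H-pyrazol-1-yl on an aromatic carbon. Among the compounds with values here, no measured step bears readably on this change. For compound 4 the expected step that the limit leaves unreadable from compound 1 to compound 4 is an estimate that rests on the limits alone, and compound 4 is expected again to report a limit. Compound 4 is estimated at 3000 nM, with a range from 500 nM to 15000 nM.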

Compound 4, solubility: < 5000 nM
Compound 4: no number, only a limit; the forecaster's own chance of this, stated with the estimate: 70%; the middle value does not contradict the limit.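

Compound 4 also reports only a limit in this assay, so no step linking it with compound 1, compound 2 or compound 3 can be read: the limit of < 5000 nM in this assay, at which 4 of the 4 values shown sit.

The compounds shown leave open how these four differ in solubility, and whether any change of group on the shared core shifts it.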